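This account rests on a few compounds, and the source may have more. Where it says the series, first, only, none or still open, it means among the compounds named here.

Of the compounds shown here, three have been measured so far in a functional assay on K562 cells (Homo sapiens) for antiproliferative activity, read by MTT assay; a higher number here means a weaker inhibitor, a lower number a stronger inhibitor. Compound 1 (`Oc1nc(-c2ccc(F)cc2)nc2ccccc12`), built on a different core, gives 17000 nM. Compound 2 (`CCCc1nn(C)c2c(=O)[nH]c(-c3ccc(Cl)cc3)nc12`) gives 15000 nM, and compound 3 (`CCCc1nn(C)c2c(=O)[nH]c(-c3cccc(Cl)c3)nc12`) gives 16000 nM. The value of compound 3 lies within the usual scatter of both others, so it cannot be separated from either of them.

Compound 4 (`CCCc1nn(C)c2c(=O)[nH]c(-c3ccc(C)cc3)nc12`) keeps the core of compound 3 and changes one group: 4-methylphenyl in place of 3-chlorophenyl on an aromatic carbon. In words, 4-methylphenyl takes the place of 3-chlorophenyl on an aromatic carbon. Within the data shown here, the one measured step that bears on this put 3-chlorophenyl in place of 4-chlorophenyl, and it came to a 1.1-fold higher number from compound 2 to compound 3 (0.03 log units; within the scatter). Among the measured compounds shown here, no measured compound carries 4-methylphenyl, so that group remains untested and the evidence is thin. For the measured compounds named here, with only that small step to go on, no change beyond the scatter is expected in this assay, in either direction. The expected step is a 1.1-fold lower number from compound 3 to compound 4 (0.03 log units; within the scatter). Compound 4 is estimated at 15000 nM, with an expected range of 8000 nM to 30000 nM.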

Compound 4, half-maximal inhibitory concentration: 19000 nM
Compound 4: middle estimate off by 1.3-fold (0.10 log units), on the low side; the range from low to high includes it.
By their numbers in this assay, from the lowest: compounds 2, 3, 1 and 4 (each within the scatter of the next).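

In this assay, among these compounds, the new compound gives the first direct exchange of chloro for methyl on the phenyl group, a 1.3-fold higher number from compound 2 to compound 4 (0.10 log units; within the scatter), so that swap cannot be told apart from no change. The other step, a 1.2-fold higher number from compound 3 to compound 4 (0.07 log units; within the scatter), also involves a move from 3-chlorophenyl to 4-methylphenyl and likewise stays within the usual scatter, so this position has now accepted a methyl as well as a chloro without a clear shift in the number. The data offer no measurement that explains this flat behaviour.

From the compounds shown here alone, it remains open whether any group on this phenyl ring can move the number beyond the scatter, for example an amine or a carboxylic acid. The effect of a longer chain in place of the propyl group on the shared core is also unknown.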